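Hydroxy for isopropyl on a para-substituted hydrazone series

The source may report more compounds than this note shows. Statements on the series, on what has been measured and on what is new or still open speak of the compounds shown alone.

Compound 1: `Cn1nnnc1SCC(=O)N/N=C/c1ccc([N+](=O)[O-])cc1`, 632000 nM
Compound 2: `CC(C)c1ccc(/C=N/NC(=O)CSc2nnnn2C)cc1`, 400000 nM

Of the compounds shown here, two sharing a common core have been measured in a functional assay on A549 cells (Homo sapiens) for cytotoxicity, read by XTT assay, with a stated time of 24 h; on this read-out lower numbers stand for stronger inhibition and higher numbers for weaker inhibition. Compound 1 gives 632000 nM in this assay, and compound 2 gives 400000 nM. For the measured compounds named here, the only measured step, a 1.6-fold lower number from compound 1 to compound 2 (0.20 log units; within the scatter), is within the scatter, so compound 2 and compound 1 cannot be set apart on these numbers.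

Compound 3, `Cn1nnnc1SCC(=O)N/N=C/c1ccc(O)cc1`, is not yet measured. It differs from compound 2 by hydroxy in place of isopropyl on an aromatic carbon. Going by the values given here, no measured step involves a hydroxy group; the single step available, a 1.6-fold lower number from compound 1 to compound 2 (0.20 log units; within the scatter), exchanged groups at the same place without moving the number beyond the scatter. On that basis compound 3 is expected to stay close to compound 2, with the step of a 1.3-fold higher number from compound 2 to compound 3 (0.10 log units; within the scatter) expected to lie within the scatter. The estimate for compound 3 in this assay is 500000 nM, ranging from 200000 nM to 1500000 nM.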

Compound 3, half-maximal inhibitory concentration: > 10000000 nM
Compound 3: a limit, no number; the forecaster's own chance of this, stated with the estimate: 25%; at least 20-fold (1.30 log units) between middle value and limit.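

At this place on the aromatic carbon, the exchange of nitro and isopropyl had left the number within the scatter, so the position looked indifferent to its group. Hydroxy shows that it is not: in this assay there is an at least 25-fold higher number from compound 2 to compound 3 (1.39 log units; beyond the scatter) and an at least 15-fold higher number from compound 1 to compound 3 (1.19 log units; beyond the scatter), both beyond the scatter, which makes compound 3 the weakest of the three. Compound 3 stands at a limit of the assay, not at a number: the limit of > 10000000 nM in this assay, at which 1 of the 3 values shown sits.

Hydroxy brings a hydrogen-bond donor where isopropyl has none, but the compounds shown do not tell whether that donor accounts for the step. From the compounds shown here alone, it also remains open how an amine or a methoxy group at this place would read, and so whether this step is peculiar to hydroxy.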